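Ethoxycarbonyl to methoxycarbonyl: from compound 1 to compound 4

The source may report more compounds than this note shows. Statements on the series, on what has been measured and on what is new or still open speak of the compounds shown alone.

Measured so far in an assay for inhibition of Fatty-acid amide hydrolase 1 (Rattus norvegicus); on this read-out higher numbers stand for weaker inhibition and lower numbers for stronger inhibition:
compound 1 `CCOC(=O)c1cccc(-c2cnc(C(=O)CCc3ccc(-c4ccccc4)cc3)o2)n1`: 3 nM
compound 2 `CN1CCN(Cc2ccc(-c3ccc(CCC(=O)c4ncc(-c5cccc(C(=O)O)n5)o4)cc3)cc2)CC1`: 1200 nM
compound 3 `O=C(O)c1ccc(-c2cnc(C(=O)CCc3ccc(COc4ccccc4)cc3)o2)nc1`: 4.6 nM

Compound 1 has the lowest of the three numbers. Compound 3 sits close to it, within the scatter, so the two are not told apart. Compound 2 lies far above both, beyond the scatter.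

Compound 4 `COC(=O)c1cccc(-c2cnc(C(=O)CCc3ccc(-c4ccccc4)cc3)o2)n1` is the next member. It differs from compound 1 in one place: hydrogen in place of methyl on a saturated chain carbon bound to an oxygen next to a carbonyl group. Among the compounds with values here, no measured pair in the set shows this change, so the expectation rests on the small size of the difference alone. The step of a 1.3-fold higher number from compound 1 to compound 4 (0.12 log units; within the scatter) is expected to fall within the scatter, with no clear direction. For compound 4 the estimate is 4 nM, in the range 1.5 nM to 12 nM.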

Compound 4, inhibition constant: 1.2 nM
Beside the measured number, compound 4's estimate is 3.3-fold (0.52 log units) above it; the whole stated range lies above it.
By their numbers in this assay, from the lowest: compound 4; then compounds 1 and 3 (each within the scatter of the next); then compound 2.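

In this assay, within the data shown here, going from ethoxycarbonyl to methoxycarbonyl gives a 2.5-fold lower number from compound 1 to compound 4 (0.40 log units; beyond the scatter), the only step so far that reads a change in one place. This position therefore registers the loss of a single methyl, and the ethyl group is not required for a low number. Nothing measured accounts for this modest step.

Going by these compounds, whether a longer chain such as propyl would continue this trend stays open. So does the effect of an amide in place of the methoxycarbonyl group.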